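The source may hold more compounds than are shown below. What is called first, only, known or untested is meant among the compounds shown, and "the series" means these compounds.

Of the compounds shown here, three have been measured in a functional assay on A-375 cells (Homo sapiens) for inhibition, read by CCK-8 assay, with a stated time of 72 h, tested at 8 uM; a higher number here means more inhibition of growth at the concentration tested, a lower number less inhibition of growth. In it, compound 1 `Nc1ccccc1NC(=O)/C=C/c1ccc(CSc2ccc(Cl)cc2)cc1` gives 48.2%, the second highest of the three numbers. Compound 3 `COc1ccc(SCc2ccc(C(=O)Nc3ccccc3N)cc2)cc1OC` gives 84.6% and compound 2 `Nc1ccccc1NC(=O)c1ccc(CSc2ccc(Br)cc2)cc1` gives 6.17%, and the gap from compound 1 to each of these two lies beyond the scatter. Compound 4 `CC(C)(C)c1ccc(SCc2ccc(/C=C/C(=O)Nc3ccccc3N)cc2)cc1` is still unmeasured and carries tert-butyl in place of chloro on an aromatic carbon of compound 1: tert-butyl in place of chloro on an aromatic carbon. Within the data shown here, no tested pair isolates this change, and the wide spread from compound 2 at 6.17% to compound 3 at 84.6% suggests no direction. The expected result is no shift beyond the scatter, with an estimated a number 1.8 percentage points higher from compound 1 to compound 4 (within the scatter). The estimate for compound 4 is 50%, within an expected range of 25% to 78%.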

Compound 4, percent growth inhibition at one concentration: 35.5%
Compound 4: the middle estimate sits 14.5 percentage points above what was measured; the measured number falls inside the stated range.
By their numbers in this assay, from the lowest: compound 2; then compound 4; then compound 1; then compound 3.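

In this assay, among these compounds, the swap of chloro for tert-butyl, on the carbon para to a large group, gives a number 12.7 percentage points lower from compound 1 to compound 4 (beyond the scatter) as the first direct reading at this position. The change is modest: the larger group of four heavy atoms lowers growth inhibition, yet compound 4 keeps a clear part of it. Nothing available explains why the number falls. Still open, from the compounds shown here alone, is how this position would respond to an amine or a carboxylic acid, and whether a smaller group such as methyl would match chloro.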